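A Neopentyl Cap Replaces Benzyloxy in Compound 4

This account rests on a few compounds, and the source may have more. Where it says the series, first, only, none or still open, it means among the compounds named here.

Within the data shown here, compound 3 `COc1ccnc(NC[C@@H]2C[C@@H](OCC(=O)NC[C@H](NC(=O)c3c(C)cc(C)cc3C)C(=O)O)CN2C(=O)OCc2ccccc2)c1` gives 0.54 nM in an assay on a protein complex for inhibition of integrin alpha-5/beta-1 (Homo sapiens), read by ELISA (on this read-out lower numbers stand for stronger inhibition and higher numbers for weaker inhibition), the lowest of the three numbers measured so far, although its gap to each of the other two stays within the scatter. Compound 1 `COc1ccnc(NC[C@@H]2C[C@@H](OCC(=O)NC[C@H](NC(=O)C3(C)CCCCC3)C(=O)O)CN2C(=O)OCc2ccccc2)c1` gives 0.8 nM in this assay, and compound 2 `COc1ccnc(NC[C@@H]2C[C@@H](OCC(=O)NC[C@H](NC(=O)C3(C)CCCCC3)C(=O)O)CN2C(=O)CC(C)(C)C)c1` gives 0.55 nM. Compound 4 `COc1ccnc(NC[C@@H]2C[C@@H](OCC(=O)NC[C@H](NC(=O)c3c(C)cc(C)cc3C)C(=O)O)CN2C(=O)CC(C)(C)C)c1` differs from compound 3 in one place: neopentyl in place of benzyloxy on a carbonyl carbon. Among the measured compounds shown here, one measured step bears directly on this change, a 1.5-fold lower number from compound 1 to compound 2 (0.16 log units; within the scatter), the same swap at the same carbonyl carbon of the shared core. The other step, a 1.5-fold lower number from compound 1 to compound 3 (0.17 log units; within the scatter), lies elsewhere in the structure and only connects compound 1 to compound 3. Because the matching step a 1.5-fold lower number from compound 1 to compound 2 (0.16 log units; within the scatter) stayed within the scatter, a similarly small move, if any, toward a lower number is expected here, a 1.4-fold lower number from compound 3 to compound 4 (0.13 log units; within the scatter). Compound 4 is therefore estimated at 0.4 nM in this assay, with a range from 0.2 nM to 0.9 nM.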

Compound 4, half-maximal inhibitory concentration: 0.55 nM
For compound 4 the middle estimate is 1.4-fold (0.14 log units) below the measured one, and the stated range covers the measured number.
By their numbers in this assay, from the lowest: compounds 3, 2, 4 and 1 (each within the scatter of the next).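

In this assay, the swap of benzyloxy for neopentyl on the carbonyl carbon can now be read on a second core, the one carrying 2,4,6-trimethylphenyl, where the step is a 1.0-fold higher number from compound 3 to compound 4 (0.01 log units; within the scatter), and the two readings of this swap agree: the same change on two cores in this assay, a 1.5-fold lower number (0.16 log units; within the scatter) from compound 1 to compound 2 and a 1.0-fold higher number (0.01 log units; within the scatter) from compound 3 to compound 4, 1.5-fold (0.17 log units) apart, within the scatter of two such steps. The exchange of 1-methylcyclohexyl for 2,4,6-trimethylphenyl can likewise be read a second time, now with neopentyl in place, as no change at the digits printed from compound 2 to compound 4 (within the scatter), and these two readings also agree: the same change on two cores in this assay, a 1.5-fold lower number (0.17 log units; within the scatter) from compound 1 to compound 3 and no change at the digits printed (within the scatter) from compound 2 to compound 4, 1.5-fold (0.17 log units) apart, within the scatter of two such steps. Across these four compounds, then, neither change moves the number beyond the scatter on either core.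

The compounds shown carry only benzyloxy and neopentyl on this carbonyl carbon. From the compounds shown here alone, whether an amine, a carboxylic acid or a longer chain at that place would give a similar number stays open.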